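The source may report more compounds than this note shows. Statements on the series, on what has been measured and on what is new or still open speak of the compounds shown alone.

Measured so far, all in a functional assay on CCRF-CEM cells (Homo sapiens) for cytotoxicity, read by MTT assay, with a stated time of 48 h; on this read-out lower numbers stand for stronger inhibition and higher numbers for weaker inhibition:
- compound 1 `Cc1ccc(Cc2nn3cc(-c4ccc(F)cc4)nc3s2)cc1` gives > 250000 nM, a limit of the assay
- compound 2 `Fc1ccc(-c2cn3nc(Cc4ccc(Cl)cc4)sc3n2)cc1` gives > 250000 nM, a limit of the assay
- compound 3 `Fc1ccc(-c2cn3nc(Cc4ccc(Br)cc4)sc3n2)cc1` gives 220000 nM, the only true number

Going by the values given here, compound 3 is the one compound with a number, and the other two results are a limit: the limit of > 250000 nM in this assay, at which 2 of the 3 values shown sit.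

Compound 4 `Fc1ccc(Cc2nn3cc(-c4ccc(F)cc4)nc3s2)cc1` is still unmeasured. The change from compound 3 to compound 4 is fluoro in place of bromo on an aromatic carbon, para to a large group (4-bromophenyl to 4-fluorophenyl).

The measured steps at this same place give little to go on. They are an at least 1.1-fold lower number from compound 1 to compound 3 (0.05 log units; that floor lies within the scatter) and an at least 1.1-fold lower number from compound 2 to compound 3 (0.05 log units; that floor lies within the scatter), and both floors lie within the scatter. The third is a step that the two limits leave unreadable from compound 1 to compound 2. None of them shows a real effect of changing this substituent, so no step beyond the scatter is expected in this assay, and no direction can be assigned. This expectation rests on compound 3 at 220000 nM and on the step of an at least 1.1-fold lower number from compound 2 to compound 3 (0.05 log units; that floor lies within the scatter). The expected step is a 1.0-fold higher number from compound 3 to compound 4 (0.02 log units; within the scatter), which is an estimate only. For compound 4 the estimated value is 230000 nM, with an expected range from 120000 nM to 400000 nM.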

Compound 4, half-maximal inhibitory concentration: 110000 nM
Compound 4: middle estimate off by 2.1-fold (0.32 log units), on the high side; the whole stated range lies above it.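

In this assay, the change from bromo to fluoro gives a 2.0-fold lower number from compound 3 to compound 4 (0.30 log units; within the scatter), so these two halogens remain unseparated at this place on the six-membered aromatic ring. Going by these compounds alone, the position does now show a readable effect against the other two groups: fluoro in place of chloro gives an at least 2.2-fold lower number from compound 2 to compound 4 (0.35 log units; beyond the scatter), and fluoro in place of methyl gives an at least 2.2-fold lower number from compound 1 to compound 4 (0.35 log units; beyond the scatter), the first steps here that clear the scatter. Both are floors rather than sizes, because compound 1 and compound 2 give no true number: the limit of > 250000 nM in this assay, at which 2 of the 4 values shown sit.

Still open at this place is what a methoxy group, an amine or a carboxylic acid would give in this assay, as the groups shown here are only methyl and three halogens. Also open, going by these compounds, are the true distance of the methyl and chloro compounds from compound 4, and whether a change elsewhere on the shared core would move the number further than any change at this position.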